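A few compounds are considered here, and "the series" means these few. Any claim that something is new, unique, unknown or untested is made for them only; others in the source may bear on it.

Two of the compounds in this series come with numbers. In a functional assay on HEK293 cells for agonist activity at nuclear receptor subfamily 1 group D member 1 (Homo sapiens), read by a luciferase reporter, with a stated time of 24 h (on this read-out higher numbers stand for an effect only at larger amounts of compound and lower numbers for an effect already at smaller amounts), compound 1 `CC(C)(C)OC(=O)CN(Cc1ccc(F)cc1)Cc1ccc([N+](=O)[O-])s1` gives 2000 nM. In this assay compound 2 `Cc1ccc(S(=O)(=O)N(Cc2ccc(Cl)cc2)Cc2ccc([N+](=O)[O-])s2)cc1` gives 2500 nM. These two values sit within the usual scatter of each other, so together they mark one common level of activity rather than any difference between the two.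

In this assay compound 3 `O=C(Oc1ccccc1)N1CCC(CN(Cc2ccc(Cl)cc2)Cc2ccc([N+](=O)[O-])s2)C1` gives "not determined" (no result reported), so it stands nowhere on this scale; its structure resembles those of compounds 1 and 2 over much of its framework, but nothing measured can be attached to it.

Compound 4 `O=[N+]([O-])c1ccc(CN(Cc2ccc(Cl)cc2)CC2CCN(S(=O)(=O)Cc3ccccc3)C2)s1` differs from compound 3 in one place: benzylsulfonyl in place of phenoxycarbonyl on an amine nitrogen in a ring. Within the data shown here, no measured pair shows the effect of such an exchange, and compound 3 itself offers no starting number, so the size and direction of this step cannot be read from the data; the only anchor is the common level that compound 1 reaches with 2000 nM and compound 2 with 2500 nM. Compound 4 is expected to land near that level, at an estimated 2500 nM in this assay, within a range from 800 nM to 8000 nM.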

Compound 4, half-maximal effective concentration: 630 nM
Beside the measured number, compound 4's estimate is 4.0-fold (0.60 log units) above it; the measured number lies below the stated range.
By their numbers in this assay, from the lowest: compound 4; then compounds 1 and 2 (each within the scatter of the next).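

Among these compounds, no step can be read for compound 4, as compound 3, the one compound differing from it in one place, offers no number to start from in this assay. Nothing shown here accounts for the value of compound 4. The compounds shown leave open whether benzylsulfonyl or phenoxycarbonyl on that ring nitrogen gives the lower number.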